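This account rests on a few compounds, and the source may have more. Where it says the series, first, only, none or still open, it means among the compounds named here.

Measured compounds:
Compound 1, `Fc1cccc2c1C1CNCC2C1`: 200 nM
Compound 2, `c1ccc(-c2cccc3c2C2CNCC3C2)cc1`: 1600 nM
Compound 3, `c1ccc(Cc2nc3cc4c(cc3o2)C2CNCC4C2)cc1`: 34 nM

Among the three compounds tested in an assay on HEK293 cells for binding affinity to Neuronal acetylcholine receptor; alpha4/beta2 (Homo sapiens) (on this read-out higher numbers stand for weaker inhibition and lower numbers for stronger inhibition), compound 2 gives the highest number, 1600 nM. Its nearest neighbour is compound 1, which in this assay gives 200 nM, and the furthest is compound 3, which gives 34 nM.

The change now considered starts from compound 2 and leads to compound 4, `FC(F)(F)c1cccc2c1C1CNCC2C1`, a compound not yet measured. The change is trifluoromethyl in place of phenyl on an aromatic carbon. Within the data shown here, only one measured step bears on it: the replacement of fluoro by phenyl on an aromatic carbon, which gave an 8.0-fold higher number from compound 1 to compound 2 (0.90 log units; beyond the scatter). Compound 4 reverses that enlargement, since it and compound 1 differ only in trifluoromethyl against fluoro. The step from compound 1 to compound 2 therefore suggests that removing phenyl should bring the number back down, and compound 4 is expected to land near compound 1 rather than near compound 2. The estimate for compound 4 in this assay is 250 nM, with a range from 80 nM to 800 nM. This expected result corresponds to a 6.4-fold lower number from compound 2 to compound 4 (0.81 log units; beyond the scatter).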

Compound 4, inhibition constant: 39 nM
For compound 4 the middle estimate is 6.4-fold (0.81 log units) above the measured one; measured number below the stated range.
By their numbers in this assay, from the lowest: compounds 3 and 4 (each within the scatter of the next); then compound 1; then compound 2.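

In this assay, trifluoromethyl in place of phenyl on this aromatic carbon gives a 41-fold lower number from compound 2 to compound 4 (1.61 log units; beyond the scatter) and so shows that this position can carry a group that lowers the number well past the level set by fluoro, which the earlier pair could not show. Trifluoromethyl in place of fluoro gives a 5.1-fold lower number from compound 1 to compound 4 (0.71 log units; beyond the scatter) and so places the three groups in an order, all steps beyond the scatter, that does not follow heavy-atom count: trifluoromethyl, with more heavy atoms than fluoro and fewer than phenyl, gives the lowest number of the three, and the removal of phenyl is therefore not merely a return to the fluoro level. No accompanying measurement on these compounds accounts for this order.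

The compounds shown leave open whether a methyl, a methoxy or a nitrile on the same carbon would stay near compound 4 or fall back towards compound 1, and so whether the fluorines of trifluoromethyl matter at all. They also leave open how trifluoromethyl would fare on the other aromatic carbons of the shared core, since compound 3 differs from compound 4 in more than one place and offers no direct comparison.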